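Swapping a thiophene for a methylpyrazole on a chalcone

The source may hold more compounds than are shown below. What is called first, only, known or untested is meant among the compounds shown, and "the series" means these compounds.

Compound 1 `O=C(/C=C/c1cccs1)c1cc(O)c(O)c([N+](=O)[O-])c1` is a chalcone carrying a nitrocatechol. In an assay on isolated protein for inhibition of Amine oxidase [flavin-containing] B (Homo sapiens), read by fluorescence (on this read-out higher numbers stand for weaker inhibition and lower numbers for stronger inhibition), compound 1 gives 62900 nM. Compound 2 `CC(=O)N1N=C(c2cc(O)c(O)c([N+](=O)[O-])c2)CC1c1ccoc1` gives 126000 nM in this assay, and the two numbers lie within the usual scatter of each other, so neither stands apart. Compound 3 `Cn1cc(/C=C/C(=O)c2cc(O)c(O)c([N+](=O)[O-])c2)cn1` differs from compound 1 by one change: 1-methyl-1H-pyrazol-4-yl in place of thiophen-2-yl on a double-bonded chain carbon bound to a double-bonded chain carbon. Within the data shown here, with no comparable step measured, the expected step from compound 1 to compound 3, a 1.3-fold higher number from compound 1 to compound 3 (0.10 log units; within the scatter), is estimated to stay within the scatter. Compound 3 is therefore expected to give about 80000 nM in this assay, likely between 25000 nM and 250000 nM.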

Compound 3, half-maximal inhibitory concentration: 66200 nM
Compound 3: the middle estimate sits 1.2-fold (0.08 log units) above what was measured; measured number inside the range.
By their numbers in this assay, from the lowest: compounds 1, 3 and 2 (each within the scatter of the next).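

On this double-bonded chain carbon, 1-methyl-1H-pyrazol-4-yl in place of thiophen-2-yl gives a 1.1-fold higher number from compound 1 to compound 3 (0.02 log units; within the scatter) in this assay and so leaves the number where it was. The entering ring has 2 hetero atoms and a methyl group, yet this first measured step at the position shows no change beyond the scatter. No measurement here explains why the two rings read alike.

As far as these compounds go, whether an amine, a carboxylic acid or a longer chain at this place would move the number beyond the scatter stays open.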